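This account rests on a few compounds, and the source may have more. Where it says the series, first, only, none or still open, it means among the compounds named here.

Among the measured compounds shown here, compound 1 `COc1cc(-c2cc(/C=C/C(=O)c3ccc(Cl)c(Cl)c3)[nH]n2)cc(OC)c1OC` gives -70% in a functional assay on SK-OV-3 cells (Homo sapiens) for cytotoxicity, read by sulforhodamine B assay, with a stated time of 48 h, tested at 100 uM (a higher number here means a weaker effect of the compound at the concentration tested, a lower number a stronger effect), and stands second highest of the three numbers so far. For the measured compounds named here, compound 3 `COc1ccc(-c2cc(/C=C/C(=O)c3ccc(N)cc3)[nH]n2)cc1` gives -68%, within the scatter of compound 1, while compound 2 `COc1ccc(-c2cc(/C=C/C(=O)c3ccc(N)cc3)[nH]n2)cc1OC` gives -99%, the only value beyond the scatter from compound 1. Going by the values given here, the sole single-point step, a number 31 percentage points higher from compound 2 to compound 3 (beyond the scatter), concerns a methoxy on the ring attached to the shared core, not the carbonyl side. Compound 4 `COc1ccc(C(=O)/C=C/c2cc(-c3cc(OC)c(OC)c(OC)c3)n[nH]2)cc1OC` differs from compound 1 as follows: 3,4-dimethoxyphenyl in place of 3,4-dichlorophenyl on a carbonyl carbon. Among the compounds with values here, no measured step bears directly on this exchange, so the expectation rests only on the methoxy-bearing compound 2 being the strongest seen. A modest downward step a number 10 percentage points lower from compound 1 to compound 4 (within the scatter) is therefore estimated, with wide uncertainty. Compound 4 is expected to give about -80%, between -100% and -55%.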

Compound 4, a percentage reported as activity, at one concentration (the size of the read-out at that concentration, not a potency): -98%
The estimate for compound 4 lay 18 percentage points above the measured number, and the stated range covers the measured number.
By their numbers in this assay, from the lowest: compounds 2 and 4 (each within the scatter of the next); then compounds 1 and 3 (each within the scatter of the next).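

At the carbonyl carbon whose other neighbours are: double-bonded chain carbon, this assay shows a number 28 percentage points lower from compound 1 to compound 4 (beyond the scatter) on replacing 3,4-dichlorophenyl with 3,4-dimethoxyphenyl. Among the compounds shown here, this is the first step at this position, and the read-out responds to the group placed there. Nothing at hand accounts for the step. From the compounds shown here alone, whether the step follows the entering methoxy groups or the leaving chlorines remains open. An unsubstituted phenyl or a 4-methoxyphenyl at the same place would help separate the two.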